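Swapping an ether for an amide on a weak kinase series

The source may hold more compounds than are shown below. What is called first, only, known or untested is meant among the compounds shown, and "the series" means these compounds.

Measured compounds:
Compound 1, `Cc1cccc2[nH]c(-c3n[nH]c4ncc(-c5cncc6ccccc56)cc34)nc12`: "not determined" (no result reported) in an assay on isolated protein for inhibition of proto-oncogene tyrosine-protein kinase receptor Ret (Homo sapiens); on this read-out higher numbers stand for weaker inhibition and lower numbers for stronger inhibition
Compound 2, `COCc1cccc2[nH]c(-c3n[nH]c4ncc(-c5cncnc5)cc34)nc12`: > 100000 nM
Compound 3, `CC(C)OCc1cccc2[nH]c(-c3n[nH]c4ncc(-c5cncc6ccccc56)cc34)nc12`: > 100000 nM

Compound 3 sits at the limit of this assay; its reading of > 100000 nM is a limit, not a number. Compound 2 is likewise reported only as the limit > 100000 nM. Compound 1 has no result. This is the state of affairs described by the limit of > 100000 nM in this assay, at which 2 of the 3 values shown sit: two of the three entries are limits, so nothing here shows a real inhibitor yet.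

Compound 4, `CCN(CC)C(=O)c1cccc2[nH]c(-c3n[nH]c4ncc(-c5cncc6ccccc56)cc34)nc12`, differs from compound 3 by diethylcarbamoyl in place of isopropoxymethyl on an aromatic carbon. Among the measured compounds shown here, with no measured step anywhere in the set, the size of the step from compound 3 cannot be read from data. Compound 4 is expected to remain weak, with an estimated step of an at least 1.6-fold lower number from compound 3 to compound 4 (0.22 log units; that floor lies within the scatter) that stays within the scatter or near it. The estimate for compound 4 is 60000 nM, ranging from 5000 nM to 300000 nM.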

Compound 4, half-maximal inhibitory concentration: 1230 nM
Compound 4: the middle estimate sits 49-fold (1.69 log units) above what was measured; the whole stated range lies above it.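

Compound 4 is the first compound here to give a real number in this assay rather than a limit: the limit of > 100000 nM in this assay, at which 2 of the 4 values shown sit.

Putting diethylcarbamoyl in place of isopropoxymethyl on this aromatic carbon gives an at least 81-fold lower number from compound 3 to compound 4 (1.91 log units; beyond the scatter), so the group at this position can strongly change the reading on the shared core. One end of that step is a limit, so its true size may be larger.

From the compounds shown here alone, it remains open whether the carbonyl or the two ethyl chains matter more. A dimethylcarbamoyl group or a carboxylic acid on the same carbon would help separate them.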